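The source may report more compounds than this note shows. Statements on the series, on what has been measured and on what is new or still open speak of the compounds shown alone.

Measured so far in a physicochemical assay for solubility, at pH 6.8; on this read-out higher numbers stand for higher solubility and lower numbers for lower solubility:
- compound 1, `CCCN(Cc1ccc(OC(F)(F)F)cc1)[C@@H]1COc2nc([N+](=O)[O-])cn2C1`, gives < 2 ug/mL, which is a limit of the assay and not a number.
- compound 2, `O=[N+]([O-])c1cn2c(n1)OC[C@@H](NCc1ccc(OC(F)(F)F)cc1F)C2`, gives 72 ug/mL.
- compound 3, `O=[N+]([O-])c1cn2c(n1)OC[C@@H](NCc1ccc(OC(F)(F)F)c(F)c1)C2`, gives 43 ug/mL.

Compound 2 thus stands at one of the two numbers the series has produced in this assay, and compound 3 sits within the usual scatter of it, so the two cannot be told apart. Compound 1 sits at the limit of < 2 ug/mL in this assay, at which 1 of the 3 values shown sits, and nothing more can be read from it. Within the data shown here, no pair among the three differs in a single place, so no measured step is available to lean on.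

Compound 4, `O=[N+]([O-])c1cn2c(n1)OC[C@@H](NCc1ccc(OC(F)(F)F)cc1Cl)C2`, is the next in line for this assay. Against compound 2 the change is chloro in place of fluoro on an aromatic carbon. With no measured step of this kind in the series, the expectation rests on compound 2 alone: a modest move downward is expected, a 2.1-fold lower number from compound 2 to compound 4 (0.31 log units; beyond the scatter), of a size that may well stay within the scatter. On that basis compound 4 is estimated at 35 ug/mL in this assay, with a range from 12 ug/mL to 90 ug/mL.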

Compound 4, solubility: 30 ug/mL
Beside the measured number, compound 4's estimate is 1.2-fold (0.07 log units) above it, within the range that was stated.
By their numbers in this assay, from the lowest: compounds 4, 3 and 2 (each within the scatter of the next, the first and the last beyond it). At a limit, below all of these: compound 1.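

In this assay, among these compounds, chloro in place of fluoro on an aromatic carbon, ortho to a large group and meta to a trifluoromethoxy group, gives the only single-place step so far: a 2.4-fold lower number from compound 2 to compound 4 (0.38 log units; beyond the scatter), a modest step. This gives the position its first measured reading, and compound 4 still returns a number and not a limit, so with chloro here the read-out stays usable for further comparison. Nothing on hand bears on the cause of this step.

Open, from the compounds shown here alone, is how this position responds to groups other than the two halogens, such as methyl, methoxy or nitrile, as a single exchange gives no trend across substituents. Also open, going by these compounds, is what the propyl group on the nitrogen does on its own: compound 2 differs in more than one place from compound 1, whose < 2 ug/mL in this assay is a limit and not a number.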